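Swapping One Halogenated Phenyl for Another on a Urea

The source may report more compounds than this note shows. Statements on the series, on what has been measured and on what is new or still open speak of the compounds shown alone.

Measured so far:
compound 1, `O=C(Nc1cccc(CNc2nccnc2Cl)c1)Nc1ccc(F)c(Cl)c1`: 4990 nM
compound 2, `CCc1ccc(NC(=O)Nc2cccc(CNc3nccnc3Cl)c2)c(CC)c1`: 6390 nM

Both compounds were tested in a functional assay on T-24 cells (Homo sapiens) for antiproliferative activity, read by MTT assay, with a stated time of 48 h; a lower number here means a stronger inhibitor, a higher number a weaker inhibitor. Compound 1 has the lower of the two numbers, with compound 2 close behind, but that gap lies within the usual scatter of repeated measurements, so the two cannot be told apart on these data. Compound 3, `O=C(Nc1cccc(CNc2nccnc2Cl)c1)Nc1ccc(Cl)cc1Br`, has not yet been measured. It differs from compound 1 in one place: 2-bromo-4-chlorophenyl in place of 3-chloro-4-fluorophenyl on an amide-type nitrogen. Among the measured compounds shown here, nothing measured here shows how such a change affects this assay; the only pair on hand, compound 1 and compound 2, differs elsewhere and shows no change beyond the scatter. The step is therefore expected to be small, in either direction or none at all, with a 1.1-fold higher number from compound 1 to compound 3 (0.04 log units; within the scatter) as the expected outcome. Compound 3 is estimated to give 5500 nM in this assay, within a range from 2000 nM to 15000 nM.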

Compound 3, half-maximal inhibitory concentration: 6650 nM
For compound 3 the middle estimate is 1.2-fold (0.08 log units) below the measured one; measured number inside the range.
By their numbers in this assay, from the lowest: compounds 1, 2 and 3 (each within the scatter of the next).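

In this assay, among the compounds shown here, this step gives the first direct reading for the aryl group on the amide-type nitrogen: 2-bromo-4-chlorophenyl in place of 3-chloro-4-fluorophenyl gives a result that cannot be told apart from the original (a 1.3-fold higher number from compound 1 to compound 3 (0.12 log units; within the scatter)). Fluorine leaves and bromine enters, and the halogens are arranged differently on the ring, yet the heavy-atom count stays the same and this swap leaves no measurable mark on the assay's read-out. No measurement on hand offers a reason for this result.

Because both halogens and their arrangement change together, the contribution of each remains unresolved. Also open, from the compounds shown here alone, is how the assay would respond to a group of a different kind on this ring, such as an amine or a carboxylic acid.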